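Benzyl for cyclohexyl on the ring nitrogen of compound 3

The source may hold more compounds than are shown below. What is called first, only, known or untested is meant among the compounds shown, and "the series" means these compounds.

Measured compounds:
compound 1 `c1ccc(-c2cn3ccnc3c(-c3ccc4ncn(C5CCCCC5)c4c3)n2)cc1`: 26.1%
compound 2 `O=Cc1ccc(-c2cn3ccnc3c(-c3ccc4ncn(C5CCCCC5)c4c3)n2)cc1`: 11.2%
compound 3 `c1ccc2c(-c3cn4ccnc4c(-c4ccc5ncn(C6CCCCC6)c5c4)n3)cccc2c1`: 14%

In a functional assay on A498 cells (Homo sapiens) for inhibition, read by sulforhodamine B assay, with a stated time of 48 h, tested at 10 uM (on this read-out higher numbers stand for more inhibition at the one concentration tested (going by the name of the read-out) and lower numbers for less inhibition), compound 3 gives 14%, the second highest of the three numbers. Its nearest neighbour is compound 2, with a gap that is within the scatter a number 2.8 percentage points higher from compound 2 to compound 3 (within the scatter), and the furthest is compound 1, which stands beyond the scatter above it a number 12.1 percentage points lower from compound 1 to compound 3 (beyond the scatter). Compound 4 `c1ccc(Cn2cnc3ccc(-c4nc(-c5cccc6ccccc56)cn5ccnc45)cc32)cc1` differs from compound 3 in one place: benzyl in place of cyclohexyl on an aromatic nitrogen. Among the measured compounds shown here, none of the measured steps touches this position; all three change the aryl group on the other ring, and the formyl step a number 14.9 percentage points lower from compound 1 to compound 2 (beyond the scatter) is of a similar modest size. For the measured compounds named here, with no step bearing on the change, no step beyond the scatter is expected no change at the digits printed from compound 3 to compound 4 (within the scatter). Compound 4 is therefore estimated at 14%, in the range 0% to 35%.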

Compound 4, a percentage reported as inhibition, at one concentration (the size of the read-out at that concentration, not a potency): 6.74%
The estimate for compound 4 lay 7.3 percentage points above the measured number; low and high end bracket the measured number.
By their numbers in this assay, from the lowest: compounds 4, 2 and 3 (each within the scatter of the next); then compound 1.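

Among the compounds shown here, the only step at this position, a number 7.3 percentage points lower from compound 3 to compound 4 (within the scatter), shows that in this assay benzyl in place of cyclohexyl on the aromatic nitrogen, an aromatic ring for a non-aromatic one, gives no change that can be told from scatter. The ring nitrogen substituent can therefore be exchanged here without a readable shift, though only at low inhibition. No available evidence explains this result.

Going by these compounds, whether benzyl would read the same on compound 1, which has the phenyl group, remains open. So does whether an amine on the benzyl ring or a longer chain on the ring nitrogen would move the number beyond the scatter.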